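Swapping the Aryl Group on a Urea Nitrogen

The source may report more compounds than this note shows. Statements on the series, on what has been measured and on what is new or still open speak of the compounds shown alone.

Compound 1 `CCN(CC)CCCNc1nc(-c2ccc(NC(=O)Nc3ccccc3Cl)cc2)nc2c(Cl)c(Cl)sc12` and compound 2 `CCN(CC)CCCNc1nc(-c2ccc(NC(=O)Nc3ccccc3Cl)cc2)nc2ccsc12` share most of their structure, but how their two cores differ is not broken down here. In a functional assay on HT-29 cells (Homo sapiens) for cytotoxicity, read by MTT assay, with a stated time of 72 h (on this read-out higher numbers stand for weaker inhibition and lower numbers for stronger inhibition), compound 1 gives 410 nM, and compound 2 gives 340 nM, the two within the scatter of each other. Compound 3 `CCN(CC)CCCNc1nc(-c2ccc(NC(=O)Nc3ccc(C)cc3)cc2)nc2c(Cl)c(Cl)sc12` arises from compound 1 by 4-methylphenyl in place of 2-chlorophenyl on an amide-type nitrogen; in this assay compound 3 gives 890 nM, and a 2.2-fold higher number from compound 1 to compound 3 (0.34 log units; beyond the scatter). Compound 4 `CCN(CC)CCCNc1nc(-c2ccc(NC(=O)Nc3ccc(C)cc3)cc2)nc2ccsc12` has not been measured and arises from compound 2 by 4-methylphenyl in place of 2-chlorophenyl on an amide-type nitrogen, the same change at the same kind of place. Because the earlier step of a 2.2-fold higher number from compound 1 to compound 3 (0.34 log units; beyond the scatter) was modest, compound 4 is expected to show a 2.2-fold higher number from compound 2 to compound 4 (0.34 log units; beyond the scatter) in this assay. That expectation rests on compound 2 at 340 nM as the starting point. Compound 4 is therefore estimated at 750 nM, with a likely range from 350 nM to 1600 nM.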

Compound 4, half-maximal inhibitory concentration: 1620 nM
Estimate against measurement, compound 4: 2.2-fold (0.33 log units) below; the measured number lies above the stated range.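

In this assay, 4-methylphenyl in place of 2-chlorophenyl on an amide-type nitrogen gives a 4.8-fold higher number from compound 2 to compound 4 (0.68 log units; beyond the scatter). The change points the same way on both cores, and the two steps do not differ beyond what repeated measurement allows: the same change on two cores in this assay, a 2.2-fold higher number (0.34 log units; beyond the scatter) from compound 1 to compound 3 and a 4.8-fold higher number (0.68 log units; beyond the scatter) from compound 2 to compound 4, 2.2-fold (0.34 log units) apart, within the scatter of two such steps. Among these compounds, this shows that the direction of the change carried over between these two cores, but with only two pairs it does not show that it would carry to any other core, and it gives no cause for the higher numbers.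

The compounds shown leave open whether the step follows from losing the 2-chloro group or gaining the 4-methyl group, which 4-chlorophenyl or 2-methylphenyl at the same place could separate. They also leave open how the change would behave with a morpholine in place of the diethylamino group.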